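The compounds below may be only part of what the source reports. "The series", "measured", "known", "first", "only" and "open" are said of these compounds alone.

Two compounds have been measured so far in an ADME assay on the whole organism for pharmacokinetics, with Mus musculus as the target, at a dose of 10 mg/kg by the oral route (a higher number here means more compound in the circulation at the dose given, a lower number less compound in the circulation), and they give these values:

compound 1 (`CC/C(=C(/c1ccc(/C=C/C(=O)O)cc1)c1ccc2[nH]ncc2c1)c1ccccc1C#N`): 200 ng.h/mL
compound 2 (`CC/C(=C(/c1ccc(/C=C/C(=O)O)cc1)c1ccc2[nH]ncc2c1)c1ccc(C#N)cc1C`): 4300 ng.h/mL

Compound 2 holds the higher of these two numbers. Going by the values given here, the only measured step, a 22-fold higher number from compound 1 to compound 2 (1.33 log units; beyond the scatter), is large. That step put 4-cyano-2-methylphenyl in place of 2-cyanophenyl, so it does not show what the methyl contributes on its own.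

Compound 3 (`CC/C(=C(/c1ccc(/C=C/C(=O)O)cc1)c1ccc2[nH]ncc2c1)c1ccc(C#N)cc1Cl`) differs from compound 2 in one place only: chloro in place of methyl on an aromatic carbon. Here, chloro takes the place of methyl on an aromatic carbon, and the rest of the molecule stays the same. Among the compounds with values here, no measured step covers this exchange, so the large step above is only a weak guide to its size. The better starting point is compound 2 with 4300 ng.h/mL in this assay, and the uncertainty around it remains wide. A modest change is expected, a 1.4-fold lower number from compound 2 to compound 3 (0.16 log units; within the scatter), which would not go beyond the scatter. For compound 3 the estimated value is 3000 ng.h/mL, with an expected range of 1000 ng.h/mL to 9000 ng.h/mL.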

Compound 3, area under the concentration-time curve: 2900 ng.h/mL
Estimate against measurement, compound 3: 1.0-fold (0.01 log units) above; low and high end bracket the measured number.
By their numbers in this assay, from the lowest: compound 1; then compounds 3 and 2 (each within the scatter of the next).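

In this assay the result is a 1.5-fold lower number from compound 2 to compound 3 (0.17 log units; within the scatter), so at this place, ortho to a large group and meta to a cyano group, these numbers do not separate chloro from methyl. The high number of compound 2 therefore does not depend on methyl alone, since the change to 2-chloro-4-cyanophenyl also gives a 15-fold higher number from compound 1 to compound 3 (1.16 log units; beyond the scatter), a large step in the same direction as the one that 4-cyano-2-methylphenyl gave. Nothing available here bears on why the two groups give such similar numbers.

The large steps away from compound 1 still change two things at once, so they leave open how much comes from the new place of the nitrile and how much from the added chloro or methyl. Going by these compounds, it also remains open whether a fluoro, methoxy or trifluoromethyl group at this place would keep the number in the range of compound 2 and compound 3, or whether the same place with only a hydrogen would bring it back towards compound 1.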